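The compounds below may be only part of what the source reports. "The series", "measured", "known", "first", "only" and "open" are said of these compounds alone.

Compound 1 `CC(C)Nc1nc(O)c2cc(Cl)ccc2n1`, compound 2 `CCC(C)Nc1nc(O)c2cc(Cl)ccc2n1` and compound 3 `Oc1nc(NCC2CCCCC2)nc2ccc(Cl)cc12` have been measured in a functional assay (ileum) for inhibition, with Cavia porcellus as the target; on this read-out lower numbers stand for stronger inhibition and higher numbers for weaker inhibition. In this assay compound 1 gives 74100 nM, compound 2 gives 44700 nM and compound 3 gives 23900 nM. The change from compound 1 to compound 2 is methyl in place of hydrogen on a saturated chain carbon, two bonds along the chain from a nitrogen on an aromatic ring; the step it made, a 1.7-fold lower number from compound 1 to compound 2 (0.22 log units; within the scatter), is within the scatter. The difference between the core of compound 1 and the core of compound 3 is not broken down here.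

Compound 4 `C[C@@H](Nc1nc(O)c2cc(Cl)ccc2n1)C1CCCCC1` is not yet measured. The change from compound 3 to compound 4 is methyl in place of hydrogen on a saturated chain carbon bound to a nitrogen on an aromatic ring and a saturated ring carbon. This is the same kind of change as that from compound 1 to compound 2, not the same one: there the added methyl sat on a saturated chain carbon two bonds along the chain from a nitrogen on an aromatic ring, here it sits on a saturated chain carbon bound to a nitrogen on an aromatic ring and a saturated ring carbon. Going by the values given here, one earlier step of this kind on a different core is the only guide, and it was within the scatter, so a small step is expected for compound 4, a 1.6-fold lower number from compound 3 to compound 4 (0.20 log units; within the scatter), resting on the step from compound 1 to compound 2. Compound 4 is therefore estimated at 15000 nM in this assay, expected between 6000 nM and 40000 nM.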

Compound 4, half-maximal inhibitory concentration: 8200 nM
Compound 4: the middle estimate sits 1.8-fold (0.26 log units) above what was measured; the measured number falls inside the stated range.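

In this assay, methyl in place of hydrogen on a saturated chain carbon bound to a nitrogen on an aromatic ring and a saturated ring carbon gives a 2.9-fold lower number from compound 3 to compound 4 (0.46 log units; beyond the scatter), a modest step that stands clear of the usual scatter. Set beside the earlier methyl step, this one cannot be told apart from it, so the two cores give no sign that the change behaves differently from one to the other: the same change on two cores in this assay, a 1.7-fold lower number (0.22 log units; within the scatter) from compound 1 to compound 2 and a 2.9-fold lower number (0.46 log units; beyond the scatter) from compound 3 to compound 4, 1.8-fold (0.25 log units) apart, within the scatter of two such steps

Going by these compounds alone, this does not show that the step has one transferable size, since it rests on two pairs only, the methyl sits on a different carbon in each, and only the step to compound 4 lies beyond the scatter.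

Open, going by these compounds, is whether an ethyl or a longer chain on that same carbon would go further than the methyl of compound 4. Also open, on these data alone, is whether the mirror-image form of compound 4 would give a similar number in this assay.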